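A few compounds are considered here, and "the series" means these few. Any claim that something is new, unique, unknown or untested is made for them only; others in the source may bear on it.

Measured so far:
- compound 1 `Clc1ccc(-c2nc(N3CCCCC3)c3nc[nH]c3n2)cc1` — 1.4%
- compound 2 `CN1CCN(c2nc(-c3ccc(Cl)cc3)nc3[nH]cnc23)CC1` — 6.2%

In an assay on cells for displacement of a labelled ligand from adenosine receptor A2b (Homo sapiens), read by scintillation counting and radioligand binding, with a stated time of 30 min, tested at 10 uM (a lower number here means less inhibition, a higher number more inhibition at the concentration tested (going by the name of the read-out)), compound 1 gives 1.4%. For the measured compounds named here, the only other number is that of compound 2, which in this assay gives 6.2%; the step is a number 4.8 percentage points higher from compound 1 to compound 2 (within the scatter), so the two cannot be told apart on these numbers, and both sit at low inhibition at the tested concentration.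

Compound 3 `Clc1cccc(-c2nc(N3CCCCC3)c3nc[nH]c3n2)c1` differs from compound 1 in one place: 3-chlorophenyl in place of 4-chlorophenyl on an aromatic carbon. Going by the values given here, no measured step bears on this change. Among the compounds with values here, the one step that has been measured, from compound 1 to compound 2, concerns the replacement of piperidin-1-yl by 4-methylpiperazin-1-yl and was within the scatter; it says nothing about moving the chlorine on the phenyl ring. With both measured compounds at low inhibition and no step beyond the scatter in the series, the expectation for compound 3 is a step of a number 1.6 percentage points higher from compound 1 to compound 3 (within the scatter), that is, nothing beyond the scatter. The estimate for compound 3 in this assay is 3%, with a range from -8% to 16%.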

Compound 3, a percentage reported as inhibition, at one concentration (the size of the read-out at that concentration, not a potency): > 80%
Compound 3: a limit, no number; the forecaster's own chance of this, stated with the estimate: 0%; middle value at least 77 percentage points away from the limit.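

In this assay, the place of the chlorine on the phenyl ring matters far more than the two earlier compounds could show: 3-chlorophenyl in place of 4-chlorophenyl gives a number at least 78.6 percentage points higher from compound 1 to compound 3 (beyond the scatter). For the compounds shown here, the group that leaves and the group that enters have the same atoms and the same counts, so this step rests on the place of the chlorine alone, whereas the only earlier step, a number 4.8 percentage points higher from compound 1 to compound 2 (within the scatter), changed the piperidin-1-yl group and left the 4-chlorophenyl group in place. The result for compound 3 is a limit of the assay and not a number: the limit of > 80% in this assay, at which 1 of the 3 values shown sits.

The compounds shown leave open how far compound 3 lies past that limit, what cause lies behind the step, and whether 4-methylpiperazin-1-yl in place of piperidin-1-yl keeps the inhibition once the group is 3-chlorophenyl. They also leave open whether the chlorine itself is needed, since a 3-methoxyphenyl, 3-fluorophenyl or 3-carboxyphenyl group, or a 2-chlorophenyl group, would separate the identity of the substituent from its place on the ring.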